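Amide nitrogen substituents on a shared core

The source may hold more compounds than are shown below. What is called first, only, known or untested is meant among the compounds shown, and "the series" means these compounds.

Measured so far:
compound 1 `COC(=O)c1ccc(NC(=O)[C@@H]2CC=C(CCC=C(C)C)C[C@H]2c2ccccc2)cc1` — > 23000 nM
compound 2 `CC(C)=CCCC1=CC[C@H](C(=O)N(C)C)[C@@H](c2ccccc2)C1` — > 23000 nM
compound 3 `CC(C)=CCCC1=CC[C@H](C(=O)N(C)O)[C@@H](c2ccccc2)C1` — 2100 nM

In an assay on isolated protein for inhibition of Apoptosis regulator Bcl-2 (Homo sapiens), read by fluorescence polarization, with stated times of 5 min and 10 min (a higher number here means a weaker inhibitor, a lower number a stronger inhibitor), compound 1 gives > 23000 nM, which is a limit of the assay and not a number. Compound 2 likewise gives only a limit, > 23000 nM. Compound 3 gives 2100 nM. Within the data shown here, the single measured step, an at least 10-fold lower number from compound 2 to compound 3 (1.03 log units; beyond the scatter), also alters the substituent on an amide-type nitrogen. Compound 4 `CC(C)=CCCC1=CC[C@@H](C(N)=O)[C@H](c2ccccc2)C1` differs from compound 1 by hydrogen in place of 4-(methoxycarbonyl)phenyl on an amide-type nitrogen. Among the measured compounds shown here, no measured step removes an aryl group from this nitrogen, so the change has no direct parallel, and most values sit at the limit of > 23000 nM in this assay, at which 2 of the 3 values shown sit. For compound 4 the expected value is 20000 nM, with a range from 5000 nM to 60000 nM. This estimate implies an expected at least 1.1-fold lower number from compound 1 to compound 4 (0.06 log units; that floor lies within the scatter), with a fair chance that only a limit is again reported.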

Compound 4, inhibition constant: > 23000 nM
Compound 4: no number, only a limit; the forecaster's own chance of this, stated with the estimate: 55%; middle value at least 1.1-fold (0.06 log units) from the limit.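

In this assay, compound 1 and compound 4 each give only a limit, and the step between them cannot be read. As far as these compounds go, how hydrogen and 4-(methoxycarbonyl)phenyl on the amide-type nitrogen compare in this assay remains open.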